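Moving a Fluorine Around an Amide-Bound Phenyl Ring

The compounds below may be only part of what the source reports. "The series", "measured", "known", "first", "only" and "open" are said of these compounds alone.

Compound 1 `Cc1ccccc1N(C)C(=O)c1ccc(-c2ccc(OS(N)(=O)=O)cc2)o1` and compound 2 `Cc1ccccc1N(C)C(=O)c1ccc(-c2ccc(OS(N)(=O)=O)cc2F)o1` share one core and differ by fluoro in place of hydrogen on an aromatic carbon. In an assay on cytosol from placenta for inhibition of 17-beta-hydroxysteroid dehydrogenase type 1 (Homo sapiens), read by HPLC, with a stated time of 10 min, tested at 1 uM, in the presence of a further agent that is not named here (on this read-out lower numbers stand for less inhibition and higher numbers for more inhibition at the one concentration tested (going by the name of the read-out)), compound 1 gives 15%, and compound 2 gives 19%; the step of a number 4 percentage points higher from compound 1 to compound 2 (within the scatter) is small enough that repeated testing of the same sample could produce it. Compound 3 `Cc1cccc(F)c1N(C)C(=O)c1ccc(-c2ccc(OS(N)(=O)=O)cc2)o1` carries a 2-fluoro-6-methylphenyl on its amide-type nitrogen, but in this assay compound 3 gives "nd" (no result reported), meaning no result was reported for it, so it stands on no number at all. Compound 4 `Cc1cc(F)ccc1N(C)C(=O)c1ccc(-c2ccc(OS(N)(=O)=O)cc2)o1` is its unmeasured partner: 4-fluoro-2-methylphenyl in place of 2-fluoro-6-methylphenyl on an amide-type nitrogen. Among the compounds with values here, only one measured step exists in this set, and it concerns a fluorine on a ring other than the one changed here, so it bears on the present step only as a loose hint that a single fluorine, at the one concentration tested, moved the read-out little. With nothing from compound 3 to build on, the expectation for compound 4 rests on compound 1 and compound 2 alone. Compound 4 is therefore expected to give about 17% in this assay, with a range from 5% to 35%, and no step beyond the scatter is expected in either direction.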

Compound 4, a percentage reported as inhibition, at one concentration (the size of the read-out at that concentration, not a potency): 13%
For compound 4 the middle estimate is 4 percentage points above the measured one; the range from low to high includes it.
By their numbers in this assay, from the lowest: compounds 4, 1 and 2 (each within the scatter of the next).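

Fluoro in place of hydrogen on the phenyl ring held by the amide-type nitrogen, which gives the 4-fluoro-2-methylphenyl group, produces a number 2 percentage points lower from compound 1 to compound 4 (within the scatter) in this assay. Within the data shown here, the only earlier step put a fluorine on the other aromatic ring, so this is the first reading for the ring on the nitrogen, and here too the added fluorine leaves compound 4 indistinguishable from compound 1 at the one concentration tested. Nothing available explains this result, so the reading stays a plain observation.

From the compounds shown here alone, the step between 2-fluoro-6-methylphenyl and 4-fluoro-2-methylphenyl cannot be read, since compound 3 has no number, so it remains open whether the place of the fluorine on this ring matters at all. Also open, going by these compounds, is whether a larger change at the same place, such as a methoxy group, a chlorine or an amine on this ring in place of the fluorine, would lift the percentage clear of the usual scatter.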